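The source may hold more compounds than are shown below. What is called first, only, known or untested is meant among the compounds shown, and "the series" means these compounds.

Working notes on the series.

Compound 1 `N=C(NO)N/N=C/c1cccc(C(=N)N)c1` is the reference; in a functional assay on T-24 cells (Homo sapiens) for antiproliferative activity (a lower number here means a stronger inhibitor, a higher number a weaker inhibitor), compound 1 gives 14100 nM. Compound 2 `N=C(NN)N/N=C/c1cccc(C(=N)N)c1` carries the change (amino in place of hydroxy on an amine nitrogen), and in this assay compound 2 gives 25000 nM. The step of a 1.8-fold higher number from compound 1 to compound 2 (0.25 log units; within the scatter) is small and lies within the scatter, so nothing firm follows from this single pair.

Compound 3 `N=C(NO)N/N=C/c1cccc(C(=N)N)n1` has a different core; the difference between the two cores is not broken down here. In this assay compound 3 gives 32900 nM. Against compound 2 this is within the scatter, against compound 1 it is beyond it.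

Compound 4 `N=C(NN)N/N=C/c1cccc(C(=N)N)n1` is not yet measured. It differs from compound 3 by amino in place of hydroxy on an amine nitrogen, the same change as from compound 1 to compound 2, at the same place. On the core of compound 1 that change gave a 1.8-fold higher number from compound 1 to compound 2 (0.25 log units; within the scatter). Among the measured compounds shown here, for compound 4 a step of similar size is expected, a 1.7-fold higher number from compound 3 to compound 4 (0.22 log units; within the scatter), because the only measured instance of this change is a 1.8-fold higher number from compound 1 to compound 2 (0.25 log units; within the scatter) and it stayed within the scatter. For compound 4 in this assay the estimate is 55000 nM, with a range from 25000 nM to 120000 nM.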

Compound 4, half-maximal inhibitory concentration: 83600 nM
Compound 4: middle estimate off by 1.5-fold (0.18 log units), on the low side, within the range that was stated.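

In this assay, amino in place of hydroxy on an amine nitrogen, read on the second core, gives a 2.5-fold higher number from compound 3 to compound 4 (0.41 log units; beyond the scatter), and the gap between this step and the earlier one does not exceed what repeated measurements would give: the same change on two cores in this assay, a 1.8-fold higher number (0.25 log units; within the scatter) from compound 1 to compound 2 and a 2.5-fold higher number (0.41 log units; beyond the scatter) from compound 3 to compound 4, 1.4-fold (0.16 log units) apart, within the scatter of two such steps

Both steps run towards a higher number, so within this series the change carries from one core to the other with no measurable difference in size. This rests on just two pairs, one step within the scatter and the other beyond it, so it neither fixes the size of the step closely nor shows that the change would carry to any further core.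

The compounds shown leave open how a methoxy or a methylamino group on the same amine nitrogen would read in this assay. They also leave open whether the amidine can give way to a plain amine or a carboxylic acid on either core.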